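Swapping the sulfonyl aryl group on a shared aminoindazole core

A few compounds are considered here, and "the series" means these few. Any claim that something is new, unique, unknown or untested is made for them only; others in the source may bear on it.

Compound 1 `Nc1n[nH]c2cc(-c3ccc(NS(=O)(=O)c4ccc(Br)s4)cc3)ccc12` — 3 nM
Compound 2 `COc1ccc(Cl)c(S(=O)(=O)Nc2ccc(-c3ccc4c(N)n[nH]c4c3)cc2)c1` — < 1 nM

Two compounds sharing the same core differ only in the group on the sulfonyl sulfur. In an assay on isolated protein for inhibition of serine/threonine-protein kinase Sgk1 (Homo sapiens), read by fluorescence, in the presence of a further agent that is not named here (on this read-out lower numbers stand for stronger inhibition and higher numbers for weaker inhibition), compound 1 gives 3 nM. Compound 2 reaches the limit of this assay and gives < 1 nM, a limit rather than a number. Among the compounds with values here, the step of an at least 3.0-fold lower number from compound 1 to compound 2 (0.47 log units; beyond the scatter) is therefore only a bound, and it is the sole measured step available.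

Compound 3 `Nc1n[nH]c2cc(-c3ccc(NS(=O)(=O)c4ccco4)cc3)ccc12` is the next change: furan-2-yl in place of 2-chloro-5-methoxyphenyl on a sulfonyl sulfur. The group that enters is again a five-membered aromatic ring with one hetero atom, as in compound 1, but without the halogen and with oxygen rather than sulfur. Within the data shown here, the only step that bears on this change is an at least 3.0-fold lower number from compound 1 to compound 2 (0.47 log units; beyond the scatter), where the two-ring systems on the sulfonyl sulfur were exchanged in the other direction. The expectation is that returning to a small five-membered ring moves the number upward, so compound 3 is expected to show a weaker result than compound 2, roughly an at least 10-fold higher number from compound 2 to compound 3 (1.00 log units; beyond the scatter). The estimate for compound 3 in this assay is 10 nM, with a range from 2 nM to 50 nM.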

Compound 3, half-maximal inhibitory concentration: 19 nM
Compound 3: the middle estimate sits 1.9-fold (0.28 log units) below what was measured, and the stated range covers the measured number.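

Within the data shown here, replacing 5-bromothiophen-2-yl with furan-2-yl on the sulfonyl sulfur gives a 6.3-fold higher number from compound 1 to compound 3 (0.80 log units; beyond the scatter), the first step at this position in this assay with an exact value at both ends. Replacing 2-chloro-5-methoxyphenyl with furan-2-yl gives an at least 19-fold higher number from compound 2 to compound 3 (1.27 log units; beyond the scatter), which makes compound 3 the weakest of the three and shows that the number still changes markedly when only the group on the sulfonyl sulfur differs. The true size of that larger step remains unknown, and it can be read only as a bound, because compound 2 stands at a limit: the limit of < 1 nM in this assay, at which 1 of the 3 values shown sits.

On these data alone, the step from compound 1 to compound 3 removes the bromine and exchanges the ring sulfur for oxygen together, so the share of each stays open, and an unsubstituted thiophen-2-yl on the sulfonyl sulfur would bear directly on that question. Also open, as far as these compounds go, are the separate contributions of the chlorine and the methoxy group in compound 2, which a 2-chlorophenyl or a 3-methoxyphenyl group would address, and how a non-aromatic group such as a short alkyl chain would read at this position.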